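The source may hold more compounds than are shown below. What is called first, only, known or untested is meant among the compounds shown, and "the series" means these compounds.

Three closely related compounds have so far been measured in a functional assay on UCI101 cells (Homo sapiens) for cytotoxicity, read by resazurin assay, with a stated time of 48 h; a lower number here means a stronger inhibitor, a higher number a weaker inhibitor. Compound 1 (`COc1cc(/C=C\c2ccc3[nH]ccc3c2)cc(OC)c1`) gives 250 nM, compound 2 (`COc1cc(/C=C\c2ccc3cc[nH]c3c2)cc(OC)c1`) gives 250 nM, and compound 3 (`COc1cc(/C=C\c2ccc3[nH]cnc3c2)cc(OC)c1`) gives 260 nM. These numbers lie within the usual scatter of repeated measurements, so compound 1 stands level with the other two and no ranking can be drawn among them. The three differ in the fused part of the core, yet their numbers stay together.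

The next compound is compound 4 (`COc1cc(/C=C\c2ccc3c(ccn3C)c2)cc(OC)c1`), which has methyl in place of hydrogen on an aromatic nitrogen of a five-membered aromatic ring, part of a fused system of two rings: methyl in place of hydrogen on an aromatic nitrogen. Going by the values given here, no measured pair here shows what this change does, so any forecast has little to stand on. Among the compounds with values here, the only guide is that the three measured compounds sit so close together, with compound 1 at 250 nM as the starting point. A small shift is therefore expected, with a somewhat higher number slightly more likely than a lower one, and it may well stay within the scatter. The expected step is a 1.2-fold higher number from compound 1 to compound 4 (0.08 log units; within the scatter). For compound 4 the estimate is 300 nM, with an expected range of 130 nM to 900 nM.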

Compound 4, half-maximal inhibitory concentration: 40 nM
Beside the measured number, compound 4's estimate is 7.5-fold (0.88 log units) above it, outside the stated range (below it).
By their numbers in this assay, from the lowest: compound 4; then compounds 1, 2 and 3 (each within the scatter of the next).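

In this assay, methyl in place of hydrogen on an aromatic nitrogen gives a 6.3-fold lower number from compound 1 to compound 4 (0.80 log units; beyond the scatter), so what sits on this nitrogen matters, something the three earlier compounds, all level with one another, could not reveal. The change is small, a single carbon with no hydrogen-bond donors or acceptors, and it is the only difference between the two structures, so the whole step belongs to this one place. Nothing available shows why the number falls, so the step stands as an observation without an explanation.

The compounds shown leave open whether a longer chain on the same nitrogen, such as ethyl or propyl, or a chain ending in an amine, would keep, extend or lose this gain, since methyl is the only group seen there so far. They also leave open whether methyl on the hydrogen-bearing nitrogen of compound 2 or compound 3 would give a similar step, so this single pair cannot yet be called a pattern.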